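The source may hold more compounds than are shown below. What is called first, only, known or untested is meant among the compounds shown, and "the series" means these compounds.

Measured compounds and their values:

Compound 1, `COc1cc(/C=C/C(O)=C/C(=O)c2c(O)cccc2OC)ccc1O`, gives 3760 nM.
Compound 2, `COc1cc(/C=C/C=C/C(=O)c2ccccc2O)ccc1O`, gives 1560 nM.
Compound 3, `O=C(/C=C(O)/C=C/c1ccc(O)cc1)c1ccccc1O`, gives 1520 nM.

These three numbers come from an in vitro assay on cells for inhibition of Amine oxidase [flavin-containing] A (Homo sapiens), read by Amplex Red, with a stated time of 15 min; on this read-out higher numbers stand for weaker inhibition and lower numbers for stronger inhibition. Compound 3 has the lowest number of the three. Its nearest neighbour is compound 2, whose value sits within the scatter of compound 3, so the two cannot be told apart on this read-out. Compound 1 lies further away, beyond the scatter, with a higher number than compound 3.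

The next compound, compound 4, is `O=C(/C=C(O)/C=C/c1ccc(O)c(O)c1)c1ccccc1O`. It differs from compound 3 in one place: hydroxy in place of hydrogen on an aromatic carbon. Going by the values given here, no pair among the measured compounds shows the effect of exactly this change, so there is no measured step to lean on. Given the limited spread among the three measured compounds in this assay, the expectation is a small step, at most a modest move towards a lower number, and quite possibly none beyond the scatter.

On that basis compound 4 is expected to give about 1200 nM in this assay, with a plausible range from 400 nM to 3500 nM. This estimate corresponds to an expected step of a 1.3-fold lower number from compound 3 to compound 4 (0.10 log units; within the scatter).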

Compound 4, half-maximal inhibitory concentration: 431 nM
Estimate against measurement, compound 4: 2.8-fold (0.44 log units) above, within the range that was stated.
By their numbers in this assay, from the lowest: compound 4; then compounds 3 and 2 (each within the scatter of the next); then compound 1.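

In this assay, putting a hydroxy in place of hydrogen gives a 3.5-fold lower number from compound 3 to compound 4 (0.55 log units; beyond the scatter), a step beyond the scatter, so this aromatic carbon is a place where adding a single oxygen atom visibly changes the read-out. Going by these compounds alone, the earlier compounds offered no pair differing in only one place, so this is the first single change in the set whose size can be read directly; it applies to this arrangement, with the new hydroxy ortho to a hydroxy group and meta to a large group, and a single step does not establish a rule for aromatic hydroxy groups in general. Nothing given here bears on the reason for this drop in the number.

From the compounds shown here alone, it remains open whether the step requires a hydroxy in particular, which an amine or a fluorine on this same carbon would help to show. It is also unknown whether the same change made elsewhere on the shared core would give a step of similar size, or any step beyond the scatter at all.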